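A pyrimidine swap and the toxicity of compound 3

The source may report more compounds than this note shows. Statements on the series, on what has been measured and on what is new or still open speak of the compounds shown alone.

Among the compounds with values here, in a toxicity assay on HepG2 2.2.15 cells (Homo sapiens) for cytotoxicity, read by CellTiter-Glo (on this read-out higher numbers stand for lower toxicity in this test and lower numbers for higher toxicity in this test), compound 2 `O=C1CC(c2ccc(F)cn2)CN1c1cnn2c1CN(C(=O)Nc1cc(F)c(F)c(F)c1)C(C1CC1)C2` gives 38500 nM as the only true number so far. Compound 1 `O=C1CC(Oc2ncccn2)CN1c1cnn2c1CN(C(=O)Nc1cc(F)c(F)c(F)c1)C(C1CC1)C2` reads > 200000 nM as a limit of the assay and not a number. Compound 3 `O=C1CC(c2ncccn2)CN1c1cnn2c1CN(C(=O)Nc1cc(F)c(F)c(F)c1)C(C1CC1)C2` is still unmeasured. It keeps the core of compound 2 while one group changes: pyrimidin-2-yl in place of 5-fluoropyridin-2-yl on a saturated ring carbon in a five-membered non-aromatic ring. Within the data shown here, one measured step bears on this: an at least 5.1-fold lower number from compound 1 to compound 2 (0.71 log units; beyond the scatter) and it lies beyond the scatter while starting from a limit. Compound 1 carries the same pyrimidine ring, joined through an oxygen as (pyrimidin-2-yl)oxy, whereas compound 3 has the ring attached directly, so only part of the step of an at least 5.1-fold lower number from compound 1 to compound 2 (0.71 log units; beyond the scatter) is expected to be undone. In this assay a move towards a higher number is therefore expected, with the estimated size a 2.6-fold higher number from compound 2 to compound 3 (0.41 log units; beyond the scatter) as a modest change. For compound 3 the estimated value is 100000 nM with a range from 40000 nM to 200000 nM as the expected span.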

Compound 3, half-maximal cytotoxic concentration: > 200000 nM
Compound 3 gave a limit, no number; the forecaster's own chance of this, stated with the estimate: 30%; middle value at least 2.0-fold (0.30 log units) from the limit.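

In this assay, pyrimidin-2-yl in place of 5-fluoropyridin-2-yl on this saturated ring carbon gives an at least 5.1-fold higher number from compound 2 to compound 3 (0.71 log units; beyond the scatter), which means lower toxicity in this test. The earlier step changed both the ring and its oxygen link at once, so it could not separate the two; compound 3 has its ring attached directly, with no oxygen link, and still reads as a limit, so among these compounds the oxygen link is not needed for that reading and the identity of the ring is what tracks with the toxicity seen for compound 2. The step from compound 1 to compound 3 cannot be read, because both values are limits of the assay and not numbers: the limit of > 200000 nM in this assay, at which 2 of the 3 values shown sit.

Within the data shown here, compound 2 remains the only compound here with a true number, and the true sizes of the readable steps stay unknown. Also open, as far as these compounds go, is whether the fluorine or the ring itself goes with the lower number, which a plain pyridin-2-yl group could test, and how a phenyl ring or an amine would read on this same carbon.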